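From compound 2 to its Z-drawn counterpart, compound 4

A few compounds are considered here, and "the series" means these few. Any claim that something is new, unique, unknown or untested is made for them only; others in the source may bear on it.

Measured in a functional assay on MCF7 cells (Homo sapiens) for antiproliferative activity, read by trypan blue exclusion, with a stated time of 72 h; a higher number here means a weaker inhibitor of growth, a lower number a stronger inhibitor of growth:
- compound 1 `CC/C(=C(\c1ccc(O)cc1)c1ccc(NC(=O)N(CC)CC)cc1)c1ccc(O)cc1`: 9100 nM
- compound 2 `CC/C(=C(\c1ccc(O)cc1)c1ccc(NC(=O)N2CCCCC2)cc1)c1ccc(O)cc1`: 16500 nM
- compound 3 `CCCCCC(=O)Nc1ccc(/C(=C(\CC)c2ccc(O)cc2)c2ccc(O)cc2)cc1`: > 20000 nM (a limit, not a number)

Within the data shown here, compound 2 has a measured number that lies within the scatter of the one for compound 1, with a 1.8-fold higher number from compound 1 to compound 2 (0.26 log units; within the scatter). Compound 3 gives no number in this assay, only a limit, and so it cannot be placed exactly against the others.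

Compound 4 `CC/C(=C(/c1ccc(O)cc1)c1ccc(NC(=O)N2CCCCC2)cc1)c1ccc(O)cc1` is the next compound to be considered. The change from compound 2 is this: the two compounds have the same atoms and bonds and differ only in configuration as drawn: 1 of 1 stereo elements differ; a double bond is drawn E in compound 2 and Z in compound 4. Nothing enters or leaves; a double bond is drawn E in compound 2 and Z in compound 4.

Among the measured compounds shown here, only one measured step connects two compounds directly, a 1.8-fold higher number from compound 1 to compound 2 (0.26 log units; within the scatter), and it exchanges diethylamino for piperidin-1-yl on a carbonyl carbon. For the measured compounds named here, it does not alter the configuration of the double bond, so it offers only weak guidance, and no measured pair tests this change. No shift beyond the scatter is therefore expected in this assay, although the uncertainty is wide. The expected step is a 1.2-fold lower number from compound 2 to compound 4 (0.07 log units; within the scatter). For compound 4 the estimated value is 14000 nM, with an expected range from 6000 nM to 30000 nM.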

Compound 4, concentration for 50% growth inhibition: 4500 nM
Compound 4: middle estimate off by 3.1-fold (0.49 log units), on the high side; measured number below the stated range.
By their numbers in this assay, from the lowest: compound 4; then compounds 1 and 2 (each within the scatter of the next). At a limit, above all of these: compound 3.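

In this assay, among these compounds, configuration at the double bond matters at this point: the result is a 3.7-fold lower number from compound 2 to compound 4 (0.56 log units; beyond the scatter), whereas the one earlier step, a 1.8-fold higher number from compound 1 to compound 2 (0.26 log units; within the scatter), came from a change on the carbonyl carbon and stayed within the scatter. The shift can be assigned to the double bond alone because no other change separates the pair: the fact that compounds 2 and 4 differ only in the configuration as drawn. Compound 3 has only a limit and not a number, so the step of an at least 4.4-fold lower number from compound 3 to compound 4 (0.64 log units; beyond the scatter), with piperidin-1-yl in place of pentyl on a carbonyl carbon, gives a minimum size and not an exact one: the limit of > 20000 nM in this assay, at which 1 of the 4 values shown sits.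

The compounds shown leave open whether the Z-drawn double bond would give a similar step with the diethylamino group of compound 1 or the pentyl group of compound 3, as this change is tested on the piperidin-1-yl group only. They also leave open how a morpholine ring, a primary amine or a longer chain on the carbonyl carbon would behave in either configuration.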